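This account rests on a few compounds, and the source may have more. Where it says the series, first, only, none or still open, it means among the compounds named here.

Measured so far:
Compound 1 `C=C1C(=O)[C@@]23C(=O)OC[C@]4([C@@H](OC(C)=O)CCC(C)(C)[C@H]4C=O)[C@@H]2CC[C@H]1[C@H]3OC(=O)c1ccc(OC)cc1` — in a functional assay on MGC-803 cells (Homo sapiens) for inhibition, read by MTT assay (on this read-out lower numbers stand for stronger inhibition and higher numbers for weaker inhibition), compound 1 gives 2530 nM.
Compound 2 `C=C1C(=O)[C@@]23C(=O)OC[C@]4([C@@H](OC(C)=O)CCC(C)(C)[C@H]4C=O)[C@@H]2CC[C@H]1[C@H]3OC(=O)c1ccc(C)cc1` — in this assay compound 2 gives 1900 nM.

Compound 2 cannot be set apart from compound 1 on these numbers: the step of a 1.3-fold lower number from compound 1 to compound 2 (0.12 log units; within the scatter) lies within the scatter, so the two compounds stand together. Compound 3 `C=C1C(=O)[C@@]23C(=O)OC[C@]4([C@@H](OC(C)=O)CCC(C)(C)[C@H]4C=O)[C@@H]2CC[C@H]1[C@H]3OC(=O)CCCC` is not yet measured. It differs from compound 2 by butyl in place of 4-methylphenyl on a carbonyl carbon. Among the measured compounds shown here, the only measured step, a 1.3-fold lower number from compound 1 to compound 2 (0.12 log units; within the scatter), swaps one small group for another on the aromatic ring and says nothing about removing the ring altogether, so no measured step bears directly on this change. With no guide in the data, the expectation is that compound 3 stays near compound 2, with the step of a 1.3-fold higher number from compound 2 to compound 3 (0.12 log units; within the scatter) expected to fall within the scatter. Compound 3 is therefore estimated at 2500 nM, with a range from 900 nM to 7000 nM in this assay.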

Compound 3, half-maximal inhibitory concentration: 2490 nM
Compound 3: middle estimate off by 1.0-fold (0.00 log units), on the high side, within the range that was stated.
By their numbers in this assay, from the lowest: compounds 2, 3 and 1 (each within the scatter of the next).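

In this assay, an open chain can stand on this carbonyl carbon in place of an aromatic ring with no difference that can be told apart: butyl for 4-methylphenyl gives a 1.3-fold higher number from compound 2 to compound 3 (0.12 log units; within the scatter) and butyl for 4-methoxyphenyl gives a 1.0-fold lower number from compound 1 to compound 3 (0.01 log units; within the scatter) here. The earlier pair differed only in a small group on the ring, whereas these steps remove the ring altogether, and across these three compounds the ring is not needed to keep the number where it stands. Nothing available explains why the numbers stay together.

Open, going by these compounds, is whether a longer chain, or a chain ending in an amine or a carboxylic acid, would stay with these three compounds. Also open, on these data alone, is what a plain hydroxyl in place of the whole ester would give on the shared core.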